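The source may hold more compounds than are shown below. What is called first, only, known or untested is meant among the compounds shown, and "the series" means these compounds.

Measured in a functional assay on HeLa cells (Homo sapiens) for inhibition; a higher number here means a weaker inhibitor, a lower number a stronger inhibitor:

Compound 1 `Oc1ccc(-c2cc(-c3ccccc3F)cc(-c3ccc(O)cc3)n2)cc1`: > 50000 nM, a limit of the assay rather than a number.
Compound 2 `Oc1ccc(-c2cc(-c3cccc(F)c3)cc(-c3ccc(O)cc3)n2)cc1`: > 50000 nM, again a limit rather than a number.
Compound 3 `Oc1ccc(-c2cc(-c3ccc(F)cc3)cc(-c3ccc(O)cc3)n2)cc1`: 8680 nM.

Compound 1 therefore stands at the limit of this assay, and no number is known for it. Compound 2 stands at the same limit, so the step that the two limits leave unreadable from compound 1 to compound 2 cannot be read. Among the measured compounds shown here, the only readable steps lead to compound 3: an at least 5.7-fold lower number from compound 1 to compound 3 (0.76 log units; beyond the scatter) and an at least 5.7-fold lower number from compound 2 to compound 3 (0.76 log units; beyond the scatter). Both rest on (the limit of > 50000 nM in this assay, at which 2 of the 3 values shown sit), which is why they can only be given as lower bounds.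

Compound 4 `Oc1ccc(-c2cc(-c3ccccc3OC(F)(F)F)cc(-c3ccc(O)cc3)n2)cc1` differs from compound 1 in one place: trifluoromethoxy in place of fluoro on an aromatic carbon. For the measured compounds named here, none of the measured steps touches this kind of change; they only move a fluoro from one position of the same ring to another, and the ring that carries the change in compound 4 is the one that kept compound 1 at the limit. Going by the values given here, no measured step therefore bears directly on the step to compound 4.

With compound 1 at the limit and nothing to suggest that a larger group at that place turns the number readable, compound 4 is expected to remain near the limit, giving a step that the limit leaves unreadable from compound 1 to compound 4. The estimate for compound 4 is 60000 nM, within a range of 15000 nM to 200000 nM.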

Compound 4, half-maximal inhibitory concentration: 44600 nM
The estimate for compound 4 lay 1.3-fold (0.13 log units) above the measured number; low and high end bracket the measured number.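

Unlike compound 1, compound 4 gives a readable number in this assay, so a group at this place, ortho to a large group, does not rule out a measurable result, even with trifluoromethoxy and its 5 heavy atoms in place of fluoro and its 1. The change gives an at least 1.1-fold lower number from compound 1 to compound 4 (0.04 log units; that floor lies within the scatter), so what can be read from the floor of this step alone is no more than a difference that repeated measurements could also produce. Its true size cannot be read, because compound 1 has only a limit and no number: the limit of > 50000 nM in this assay, at which 2 of the 4 values shown sit.

Whether methoxy, with oxygen but no fluorine, or trifluoromethyl, with fluorine but no oxygen, would also give a readable number at this place remains open, so the compounds shown do not separate what the oxygen and the fluorines each contribute. From the compounds shown here alone, an amine or a carboxylic acid at this place also remains open, as does trifluoromethoxy at the places that carry fluoro in compound 2 and compound 3.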